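The source may report more compounds than this note shows. Statements on the series, on what has been measured and on what is new or still open speak of the compounds shown alone.

This piece follows a short series of compounds tested in an ADME assay on BJ cells (Homo sapiens), read by MTT assay, with a stated time of 72 h; on this read-out lower numbers stand for stronger inhibition and higher numbers for weaker inhibition. Compound 1 `COc1ncnc2c1c(I)cn2[C@@H]1O[C@H](CO)[C@@H](O)[C@H]1O` gives 91000 nM. Compound 2 `C#Cc1cn([C@@H]2O[C@H](CO)[C@@H](O)[C@H]2O)c2ncnc(OC)c12`, which carries ethynyl in place of iodo on an aromatic carbon, gives 98400 nM. Compound 3 `C#Cc1cn([C@@H]2O[C@H](CO)[C@@H](O)[C@H]2O)c2nc(N)nc(OC)c12` reaches only the limit of this assay, > 100000 nM. The step of a 1.1-fold higher number from compound 1 to compound 2 (0.03 log units; within the scatter) is within the scatter, and the step of an at least 1.0-fold higher number from compound 2 to compound 3 (0.00 log units; that floor lies within the scatter) has a floor that also lies within the scatter, as shown by the limit of > 100000 nM in this assay, at which 1 of the 3 values shown sits. Among the two numbers shown, compound 2 holds the higher one, with compound 1 within the scatter of it, and the third value is a limit.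

Compound 4 `C#Cc1cn([C@@H]2O[C@H](CO)[C@@H](O)[C@H]2O)c2ncnc(SC)c12` is not yet measured. It differs from compound 2 by methylsulfanyl in place of methoxy on an aromatic carbon. Neither measured step bears directly on this exchange: both concern other parts of the shared core, and neither moved beyond the scatter. Among the measured compounds shown here, with every value so far sitting near the upper edge of this assay, no step beyond the scatter is expected in this assay. Compound 4 is therefore expected to give about 95000 nM, with a range from 45000 nM to 150000 nM. That estimate means an expected step of a 1.0-fold lower number from compound 2 to compound 4 (0.02 log units; within the scatter), within the scatter.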

Compound 4, half-maximal inhibitory concentration: 68600 nM
Estimate against measurement, compound 4: 1.4-fold (0.14 log units) above, within the range that was stated.
By their numbers in this assay, from the lowest: compounds 4, 1 and 2 (each within the scatter of the next). At a limit, above all of these: compound 3.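

In this assay, the exchange of methoxy for methylsulfanyl gives a 1.4-fold lower number from compound 2 to compound 4 (0.16 log units; within the scatter), so this exchange of oxygen for sulfur in the group leaves the read-out within the usual scatter of the assay. Among the compounds shown here, the earlier steps concerned the iodo and ethynyl groups and an added amino group, so this is the first look at the carbon next to the ring nitrogen, and one change of the group held there does not move the number beyond the scatter. The reading carries limited weight, since it is a single exchange between two groups of the same heavy-atom count in a series that stays close to the top of what the assay can report: the limit of > 100000 nM in this assay, at which 1 of the 4 values shown sits.

What the compounds shown leave open is whether any group at this position can move the number beyond the scatter, for example an amine, a longer chain such as butylsulfanyl, or a plain hydrogen. On these data alone, it is also open whether methylsulfanyl would give a similar result on a core carrying the iodo group or the added amino group.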